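Cutting compound 1 down to compound 4

A few compounds are considered here, and "the series" means these few. Any claim that something is new, unique, unknown or untested is made for them only; others in the source may bear on it.

In an ADME assay on MDCK cells (Canis lupus familiaris) for cytotoxicity, read by MTT assay, with a stated time of 48 h (on this read-out lower numbers stand for higher toxicity in this test and higher numbers for lower toxicity in this test), compound 1 `COC(=O)[C@H](CCCNC(=N)N)NC(=O)CSc1nc(-c2ccccc2)cc(-c2ccc(C)cc2)c1C#N` gives > 250000 nM as a limit of the assay, not a number. Compound 2 `COC(=O)C[C@H](NC(=O)[C@@H](NC(=O)CSc1nc(-c2ccccc2)cc(-c2ccc(C)cc2)c1C#N)C(C)C)C(=O)OC` shares the core of compound 1. Compound 2 gives > 250000 nM as a limit too. Compound 3 `COC(=O)C[C@H](NC(=O)[C@@H](NC(=O)CSc1nc(-c2ccccc2)cc(-c2ccc(C)cc2)c1C#N)C(C)C)C(=O)N[C@@H](CCSC)C(=O)OC`, with the same core, also gives > 250000 nM as a limit. The three compounds therefore share one reading, (the limit of > 250000 nM in this assay, at which 3 of the 3 values shown sit), and none of them can be ranked against the others.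

Compound 4 `Cc1ccc(-c2cc(-c3ccccc3)nc(SCC(N)=O)c2C#N)cc1` differs from compound 1 by a single change: a hydrogen atom in place of a group of 12 heavy atoms (7 carbon, 3 nitrogen, 2 oxygen; no ring), on an amide-type nitrogen. The shared core stays in place, and only the group on that nitrogen is lost.

Among the measured compounds shown here, only one measured step comes close to this change, and it concerns a different part of the structure: a step that the two limits leave unreadable from compound 2 to compound 3. That step has no readable size, so it offers no measure and no direction for the change in this assay. No step beyond the usual scatter is therefore expected, though the data cannot exclude one.

The estimated step is an at least 1.2-fold lower number from compound 1 to compound 4 (0.09 log units; that floor lies within the scatter), and it rests on a starting point that is only a limit. Compound 4 is expected near 200000 nM, with an estimated range from 70000 nM to 500000 nM.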

Compound 4, half-maximal cytotoxic concentration: > 250000 nM
Compound 4 was reported as a limit; the forecaster's own chance of this, stated with the estimate: 60%; middle value at least 1.2-fold (0.09 log units) away from the limit.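

In this assay, compound 4 gives > 250000 nM, which is a limit and not a number. Compound 1 also sits at a limit, so no step can be read from compound 1 to compound 4: the limit of > 250000 nM in this assay, at which 4 of the 4 values shown sit.

The compounds shown leave open at what concentration any of the four becomes toxic in this assay, and whether losing the group on the amide-type nitrogen changes that concentration.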